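This account rests on a few compounds, and the source may have more. Where it says the series, first, only, none or still open, it means among the compounds named here.

Compound 1 `CC(=O)N[C@@H]1CCN(c2cc(C)nn3c(-c4ccc(C(F)(F)F)cc4)c(C)nc23)C1` was examined in an ADME assay on microsomes from liver (Mus musculus) for metabolic stability, read by LC-MS, with NADPH named in the record, with a stated time of 60 min, tested at 1 uM, in the absence of a further agent (on this read-out higher numbers stand for a more stable compound and lower numbers for a less stable compound), alongside compound 2 `CC(=O)N[C@@H]1CCN(c2cc(C)nn3c(-c4cccc(S(=O)(=O)N(C)C)c4)c(C)nc23)C1`. In this assay compound 1 gives > 95% as a limit of the assay and not as a number. Compound 2 gives > 95% and this too is a limit. The record so far is thus the limit of > 95% in this assay, at which 2 of the 2 values shown sit, and it gives compound 1 no exact number as a starting point.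

Compound 3 `CC(=O)N[C@@H]1CCN(c2cc(C)nn3c(-c4ccco4)c(C)nc23)C1` has not been measured yet. It carries furan-2-yl in place of 4-(trifluoromethyl)phenyl on an aromatic carbon and otherwise matches compound 1. For the measured compounds named here, no step between measured compounds that differ in one place is available to size this change in this assay so any figure here is an expectation. Going by the values given here, with the limit of > 95% in this assay, at which 2 of the 2 values shown sit, as the only guide, a modest fall in the percent remaining is expected, perhaps not far beyond the scatter, and a reading at the same limit remains possible. The estimated change is a number at least 10 percentage points lower from compound 1 to compound 3 (that floor lies within the scatter) and it is counted from a limit, not from a number. For compound 3 the estimated percent remaining is 85% with an expected range from 60% to 98% in this measurement.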

Compound 3, percent of the compound remaining: > 95%
Compound 3 was reported as a limit; the forecaster's own chance of this, stated with the estimate: 35%; middle value at least 10 percentage points from the limit.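

In this assay compound 3 gives > 95%, which is a limit and not a number. No step from compound 1 to compound 3 can be read, because both values are limits: the limit of > 95% in this assay, at which 3 of the 3 values shown sit.

The compounds shown leave open how far furan-2-yl and 4-(trifluoromethyl)phenyl differ in percent remaining, since none gives an exact reading.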